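The source may report more compounds than this note shows. Statements on the series, on what has been measured and on what is new or still open speak of the compounds shown alone.

In a functional assay on the whole organism (Tail, strain ICR) with Mus musculus as the target, in the tail flick test, with a stated time of 150 min, at a dose of 25 umol/kg by the oral route (a higher number here means a stronger effect of the compound at the dose given, a lower number a weaker effect), compound 1 `O=C(CN(c1nc(Cl)nc2[nH]cnc12)C1CC1)NCC(=O)OCc1ccccc1` gives 18%, compound 2 `CC(C)[C@H](NC(=O)CN(c1nc(Cl)nc2[nH]cnc12)C1CC1)C(=O)OCc1ccccc1` gives 17.9%, and compound 3 `N=C(N)NCCC[C@H](NC(=O)CN(c1nc(Cl)nc2[nH]cnc12)C1CC1)C(=O)OCc1ccccc1` gives 6.12%. Compound 3 thus stands lowest of the three: the step of a number 11.9 percentage points lower from compound 1 to compound 3 (beyond the scatter) and the step of a number 11.8 percentage points lower from compound 2 to compound 3 (beyond the scatter) both lie beyond the scatter, whereas the step of a number 0.1 percentage points lower from compound 1 to compound 2 (within the scatter) lies within it. Compound 4 `NCCCC[C@H](NC(=O)CN(c1nc(Cl)nc2[nH]cnc12)C1CC1)C(=O)OCc1ccccc1` differs from compound 3 in a single place: a group of 2 heavy atoms (1 carbon, 1 nitrogen; no ring) in place of a group of 4 heavy atoms (1 carbon, 3 nitrogen; no ring), on a saturated chain carbon, four bonds along the chain from an amide-type nitrogen and a carbonyl carbon. Going by the values given here, none of the measured steps touches this place; all three sit on the saturated chain carbon bound to an amide-type nitrogen and a carbonyl carbon, and together they show only that the group of 7 heavy atoms at that carbon goes with the lowest number, while hydrogen and isopropyl there are indistinguishable. Among the compounds with values here, compound 4 keeps a chain at that carbon and exchanges only its end, so no measured step points firmly up or down. The step of a number 3.9 percentage points higher from compound 3 to compound 4 (within the scatter) is therefore expected to be small, with a slight lean upward. Compound 4 is estimated at 10%, within a range from 3% to 22%.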

Compound 4, a percentage reported as activity, at one dose (the size of the read-out at that dose, not a potency): 9.88%
Estimate against measurement, compound 4: 0.1 percentage points above; low and high end bracket the measured number.
By their numbers in this assay, from the lowest: compounds 3, 4, 2 and 1 (each within the scatter of the next, the first and the last beyond it).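

In this assay, exchanging the end of the chain does not separate the two compounds: the result is a number 3.8 percentage points higher from compound 3 to compound 4 (within the scatter). Unlike compound 3, compound 4 with its 4-aminobutyl chain is not set apart from the compounds carrying hydrogen or isopropyl on the saturated chain carbon bound to an amide-type nitrogen and a carbonyl carbon, the steps being a number 8.1 percentage points lower from compound 1 to compound 4 (within the scatter) and a number 8 percentage points lower from compound 2 to compound 4 (within the scatter). No measurement is available that could explain these numbers.

From the compounds shown here alone, it remains open whether a shorter amine chain or a carboxylic acid at the chain end would give a number beyond the scatter from these compounds. Going by these compounds, the behaviour of the series at other doses and times also remains open.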